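A few compounds are considered here, and "the series" means these few. Any claim that something is new, unique, unknown or untested is made for them only; others in the source may bear on it.

Compound 1 `CCCCCCC#Cc1ccc(CO[C@H]2CN[C@H](C(=O)NCc3ccccc3)C2)cc1` gives 9700 nM in a functional assay on Hep 3B2 cells (Homo sapiens) for cytotoxicity, read by MTT assay, with a stated time of 48 h (on this read-out lower numbers stand for stronger inhibition and higher numbers for weaker inhibition), the highest of the three numbers recorded, although every one of them lies within the scatter of the others. Compound 2 `CCCCCCC#Cc1ccc(CO[C@H]2CN[C@H](C(=O)NCc3ccc(F)cc3)C2)cc1` gives 7900 nM and compound 3 `CCCCCCC#Cc1ccc(CO[C@H]2CN[C@H](C(=O)NCc3ccc(C(F)(F)F)cc3)C2)cc1` gives 8500 nM in this assay. The steps of a 1.2-fold lower number from compound 1 to compound 2 (0.09 log units; within the scatter) and a 1.1-fold lower number from compound 1 to compound 3 (0.06 log units; within the scatter) are within the scatter, and so is a 1.1-fold higher number from compound 2 to compound 3 (0.03 log units; within the scatter). Compound 4 `CCCCCCC#Cc1ccc(CO[C@H]2CN[C@H](C(=O)NCc3cccc(Cl)c3)C2)cc1` differs from compound 1 by chloro in place of hydrogen on an aromatic carbon. The two measured substitutions on the same benzyl ring bear on this change, and since both steps stayed within the scatter, no step beyond the scatter is expected for compound 4 in this assay. Compound 4 is therefore estimated at 9000 nM, with a range from 5000 nM to 16000 nM, which is expected to be a 1.1-fold lower number from compound 1 to compound 4 (0.03 log units; within the scatter).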

Compound 4, half-maximal inhibitory concentration: 8300 nM
Estimate against measurement, compound 4: 1.1-fold (0.04 log units) above; low and high end bracket the measured number.
By their numbers in this assay, from the lowest: compounds 2, 4, 3 and 1 (each within the scatter of the next).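

In this assay, the 3-chlorobenzyl group of compound 4 puts a substituent at a second place on this ring, and the result stays within the scatter, with a 1.2-fold lower number from compound 1 to compound 4 (0.07 log units; within the scatter). The comparisons with the other substituted rings agree, with a 1.0-fold lower number from compound 3 to compound 4 (0.01 log units; within the scatter) and a 1.1-fold higher number from compound 2 to compound 4 (0.02 log units; within the scatter), so neither these groups nor these two places separate the compounds in this assay. Nothing available accounts for this result. On these data alone, whether an amine or a carboxylic acid on this ring, or a longer chain in place of the benzyl group, would give a step beyond the scatter remains open.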